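This account rests on a few compounds, and the source may have more. Where it says the series, first, only, none or still open, it means among the compounds named here.

The compounds share one core and differ only in the group held on an aromatic carbon of a five-membered aromatic ring with 3 nitrogen. Compound 1 `CCS[C@@H]1[C@H](SCC)[C@@H](Cn2cc(-c3ccccc3)nn2)O[C@H]1n1cc(C)c(=O)[nH]c1=O` carries a phenyl there, and in a functional assay on A549 cells (Homo sapiens) for cytotoxicity, read by MTT assay, with a stated time of 72 h (on this read-out higher numbers stand for an effect only at larger amounts of compound and lower numbers for an effect already at smaller amounts), compound 1 gives 31700 nM. For the measured compounds named here, compound 2 `CCS[C@@H]1[C@H](SCC)[C@@H](Cn2cc(-c3ccccc3C(F)(F)F)nn2)O[C@H]1n1cc(C)c(=O)[nH]c1=O` carries a 2-(trifluoromethyl)phenyl instead, and in this assay compound 2 gives 7230 nM, the lowest of the two numbers measured so far. Going by the values given here, the single measured step, a 4.4-fold lower number from compound 1 to compound 2 (0.64 log units; beyond the scatter), came from trifluoromethyl in place of hydrogen on an aromatic carbon. Compound 3 `CCOC(=O)c1cn(C[C@H]2O[C@@H](n3cc(C)c(=O)[nH]c3=O)[C@H](SCC)[C@@H]2SCC)nn1` alters the same aromatic carbon differently: ethoxycarbonyl in place of 2-(trifluoromethyl)phenyl on an aromatic carbon. Among the compounds with values here, no measured step removes the aromatic ring altogether, so the step from compound 1 to compound 2 is only a loose guide, showing that this group can shift the number by a modest amount. Compound 3 is therefore expected to give about 30000 nM in this assay, most likely between 8000 nM and 100000 nM. That estimate corresponds to a 4.1-fold higher number from compound 2 to compound 3 (0.62 log units; beyond the scatter).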

Compound 3, half-maximal effective concentration: >= 100000 nM
Compound 3: no number, only a limit (the forecaster's own chance of this, stated with the estimate: 20%); middle value at least 3.3-fold (0.52 log units) away from the limit.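

Compound 3 gives no number in this assay, only a limit: the limit of >= 100000 nM in this assay, at which 1 of the 3 values shown sits. Ethoxycarbonyl in place of 2-(trifluoromethyl)phenyl gives an at least 13-fold higher number from compound 2 to compound 3 (1.14 log units; beyond the scatter), and in place of phenyl it gives an at least 3.1-fold higher number from compound 1 to compound 3 (0.49 log units; beyond the scatter). The earlier compounds varied only a group on the six-membered aromatic ring, whereas this change replaces the ring itself, and among these three compounds only the two that keep a six-membered aromatic ring on this carbon give a number.

The compounds shown leave open whether the loss of the ring or the arrival of the ethoxycarbonyl matters more, as both happen in this one change. They also leave open how a carboxylic acid, an amine or a simple longer carbon chain on this carbon would read.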